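Chloro Added to an Aromatic Carbon in Compound 4

This account rests on a few compounds, and the source may have more. Where it says the series, first, only, none or still open, it means among the compounds named here.

The measured compounds, read in a functional assay on CHO cells for positive allosteric modulation of metabotropic glutamate receptor 2 (Homo sapiens), read by scintillation counting and GTPgammaS binding, with a stated time of 30 min; on this read-out lower numbers stand for smaller maximal responses and higher numbers for larger maximal responses:
compound 1 `CC(C)CCn1ccc(-c2ccc(OCC3CC3)cc2)c(C#N)c1=O` gives 192%
compound 2 `CC(C)CCn1ccc(-c2ccc(OCC3CC3)c(Cl)c2)c(C#N)c1=O` gives 206%
compound 3 `CCCCn1ccc(-c2ccc(Oc3ccnc(C)c3)cc2)c(C#N)c1=O` gives 243%

Compound 1 and compound 2 differ in one place: chloro in place of hydrogen on an aromatic carbon. This change brought a number 14 percentage points higher from compound 1 to compound 2 (beyond the scatter). Compound 3 shows the highest number of the three, beyond the scatter against both compound 1 and compound 2. The difference between the core of compound 3 and the core of compound 1 is not broken down here.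

Compound 4 `CCCCn1ccc(-c2ccc(Oc3ccnc(C)c3)c(Cl)c2)c(C#N)c1=O` has not been measured. It differs from compound 3 by chloro in place of hydrogen on an aromatic carbon. Within the data shown here, this is the same kind of change as the one from compound 1 to compound 2, though the place is not the same: in compound 2 the chloro stands ortho to a cyclopropylmethoxy group, in compound 4 ortho to a (2-methylpyridin-4-yl)oxy group, meta to a large group in both. Because compound 3 already gives 243%, and the earlier step of a number 14 percentage points higher from compound 1 to compound 2 (beyond the scatter) was modest, a step of a number 12 percentage points higher from compound 3 to compound 4 (beyond the scatter) is expected in this assay. Compound 4 is therefore estimated at 255%, expected to lie between 225% and 290%.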

Compound 4, largest response reached (Emax), in percent of the reference or control that the assay uses: 245%
Beside the measured number, compound 4's estimate is 10 percentage points above it; the measured number falls inside the stated range.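

On the core of compound 3, chloro in place of hydrogen on an aromatic carbon, here ortho to a (2-methylpyridin-4-yl)oxy group, brought a number 2 percentage points higher from compound 3 to compound 4 (within the scatter) in this assay, so no effect of the change can be told from the scatter on this core. Set beside the earlier step, the result gives no sign that the change acts differently on the two cores: the same change on two cores in this assay, a number 14 percentage points higher (beyond the scatter) from compound 1 to compound 2 and a number 2 percentage points higher (within the scatter) from compound 3 to compound 4, 12 percentage points apart, within the scatter of two such steps This does not show that the change carries over unaltered, since two pairs are too few for that, the earlier step lies beyond the scatter while the new one does not, and the two cores differ in more than one place.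

The compounds shown leave open what fluoro, methoxy or an amine would do on the same aromatic carbon. They also leave open how the chloro step would read on a further core, such as one with a carboxylic acid on the (2-methylpyridin-4-yl)oxy group.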